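This account rests on a few compounds, and the source may have more. Where it says the series, first, only, none or still open, it means among the compounds named here.

Measured in a functional assay on MCF7 cells (Homo sapiens) for cytotoxicity, read by MTT assay, with a stated time of 72 h; a higher number here means a weaker inhibitor, a lower number a stronger inhibitor:
Compound 1 `COc1cccc(/C=C2\CCC/C(=C\c3ccccc3Br)C2=O)c1OC` gives 9700 nM
Compound 2 `COc1cccc(/C=C2\CCC/C(=C\c3ccc(Br)cc3)C2=O)c1OC` gives 13800 nM
Compound 3 `COc1cccc(/C=C2\CCC/C(=C\c3ccc(Cl)c(Cl)c3)C2=O)c1OC` gives 9000 nM

Compound 3 does not separate from the other two compounds in this assay. Both a 1.1-fold lower number from compound 1 to compound 3 (0.03 log units; within the scatter) and a 1.5-fold lower number from compound 2 to compound 3 (0.19 log units; within the scatter) leave it level with them, and a 1.4-fold higher number from compound 1 to compound 2 (0.15 log units; within the scatter) likewise divides nothing.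

Compound 4 `COc1cccc(/C=C2\CCC/C(=C\c3ccc(O)c(Cl)c3)C2=O)c1OC` keeps the shared core and alters only the 3,4-dichlorophenyl group of compound 3, which becomes 3-chloro-4-hydroxyphenyl. The change is hydroxy in place of chloro on an aromatic carbon, with hydroxy in place of chloro on an aromatic carbon, ortho to a chloro group and para to a large group.

The measured steps bear on this only indirectly. Going by the values given here, they exchange 2-bromophenyl, 4-bromophenyl and 3,4-dichlorophenyl for one another, and none of them brings in a hydroxy group, so the data offer no direct precedent. Still, the closest evidence is small, as a 1.5-fold lower number from compound 2 to compound 3 (0.19 log units; within the scatter) shows, so no step beyond the scatter is expected in this assay. The expected change is a 1.2-fold lower number from compound 3 to compound 4 (0.08 log units; within the scatter), and its direction is not firmly estimated. For compound 4 the estimated value is 7500 nM, with an expected range from 3000 nM to 18000 nM.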

Compound 4, half-maximal inhibitory concentration: 16400 nM
For compound 4 the middle estimate is 2.2-fold (0.34 log units) below the measured one; the measured number falls inside the stated range.
By their numbers in this assay, from the lowest: compounds 3, 1, 2 and 4 (each within the scatter of the next).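

In this assay, hydroxy in place of chloro, on an aromatic carbon ortho to a chloro group and para to a large group, is the first change shown that brings a hydrogen-bond donor and acceptor to this aryl group, and a 1.8-fold higher number from compound 3 to compound 4 (0.26 log units; within the scatter) leaves the two compounds level. The comparisons with the bromophenyl compounds agree, since a 1.2-fold higher number from compound 2 to compound 4 (0.07 log units; within the scatter) and a 1.7-fold higher number from compound 1 to compound 4 (0.23 log units; within the scatter) also stay within the scatter, so this hydroxy group does not separate compound 4 from any of the three earlier compounds. No supporting measurement bears on why this exchange leaves the compounds level.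

The compounds shown leave open whether an amine, a carboxylic acid or a methoxy group on the same aromatic carbon would also stay level with compound 3, or would finally move the number beyond the scatter. They also leave open whether hydroxy would stay level without the chloro group beside which it is printed here, and whether any change away from this aryl group, elsewhere on the shared core, would separate these compounds.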